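A few compounds are considered here, and "the series" means these few. Any claim that something is new, unique, unknown or untested is made for them only; others in the source may bear on it.

Working notes on the series. In an ADME assay on HEK293 cells (Homo sapiens) for cytotoxicity, read by MTT assay, with a stated time of 24 h (on this read-out higher numbers stand for weaker inhibition and lower numbers for stronger inhibition), compound 2 `O=C1O/C(=C\Cn2cc(-c3ccccc3)nn2)C(OCc2ccccc2)=C1OCc1ccccc1` sits at the limit of the assay, > 100000 nM, which is a limit rather than a number. Differing from compound 2 only by hydrogen in place of methyl on an aromatic carbon, compound 1 `Cc1ccc(-c2cn(C/C=C3\OC(=O)C(OCc4ccccc4)=C3OCc3ccccc3)nn2)cc1` also returns only a limit in this assay, > 100000 nM. For the measured compounds named here, the one measured step, a step that the two limits leave unreadable from compound 1 to compound 2, therefore cannot be read, because of the limit of > 100000 nM in this assay, at which 2 of the 3 values shown sit. Going by the values given here, compound 3 `O=C1NC(O)(CCn2cc(Cc3ccccc3)nn2)C(OCc2ccccc2)=C1OCc1ccccc1`, built on a different core, gives 86000 nM in this assay, the only numeric value so far. Compound 4 `O=C1O/C(=C\Cn2cc(-c3ccccn3)nn2)C(OCc2ccccc2)=C1OCc1ccccc1` differs from compound 2 by pyridin-2-yl in place of phenyl on an aromatic carbon. Among the compounds with values here, no measured step touches this change; the only step that exists runs between two limits and tells nothing of size or direction. Compound 3 shows merely that a number within reach of this assay can occur in this set. On this basis compound 4 is expected to stay near the limit, with an expected step that the limit leaves unreadable from compound 2 to compound 4 that amounts to no change beyond the scatter. The estimate for compound 4 in this assay is 120000 nM, in the range 40000 nM to 400000 nM, and it is expected most likely to be reported again only as a limit.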

Compound 4, half-maximal inhibitory concentration: > 100000 nM
Compound 4 was reported as a limit; the forecaster's own chance of this, stated with the estimate: 80%; the middle value is on the limit's open side.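

In this assay compound 4 returns > 100000 nM, which is a limit and not a number. The steps from compound 1 and from compound 2 to compound 4 therefore cannot be read, because all three compounds rest on the same limit: the limit of > 100000 nM in this assay, at which 3 of the 4 values shown sit.

The compounds shown leave open whether pyridin-2-yl in place of phenyl changes the read-out of this assay at all.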